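Replacing the cyclopentyl group of compound 2

A few compounds are considered here, and "the series" means these few. Any claim that something is new, unique, unknown or untested is made for them only; others in the source may bear on it.

Measured in an ADME assay on microsomes from liver (Homo sapiens) for metabolic stability, with a stated time of 60 min, tested at 1 uM; on this read-out higher numbers stand for a more stable compound and lower numbers for a less stable compound:
compound 1 `CNc1nc2c(-c3ccnc(OC)c3)cnn2cc1OC`: 63%
compound 2 `COc1cc(-c2cnn3cc(OC)c(C4CCCC4)nc23)ccn1`: 32%

Of the two, compound 2 has the lower number, at 32%. Compound 3 `COc1cc(-c2cnn3cc(OC)c([C@H]4COC(C)(C)C4)nc23)ccn1` differs from it at one place: a group of 7 heavy atoms (6 carbon, 1 oxygen; one five-membered non-aromatic ring with 1 hetero atom) in place of a group of 5 heavy atoms (5 carbon; one five-membered non-aromatic ring of carbon only), on an aromatic carbon. For the measured compounds named here, the only measured step at this aromatic carbon, a number 31 percentage points lower from compound 1 to compound 2 (beyond the scatter), is large and beyond the scatter. Going by the values given here, it shows that the group here can matter, but no measured compound carries the entering group, so its guidance is weak. A moderate upward step is expected, estimated as a number 14 percentage points higher from compound 2 to compound 3 (beyond the scatter). For compound 3 the expected value is 46%, with an estimated range of 27% to 66%.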

Compound 3, percent of the compound remaining: 21%
Estimate against measurement, compound 3: 25 percentage points above; the measured number lies below the stated range.
By their numbers in this assay, from the lowest: compound 3; then compound 2; then compound 1.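

In this assay, the entering five-membered ring with 1 hetero atom does not recover what cyclopentyl lost, giving a number 11 percentage points lower from compound 2 to compound 3 (beyond the scatter). Methylamino stays clearly ahead of this group on the aromatic carbon, with a number 42 percentage points lower from compound 1 to compound 3 (beyond the scatter). No measurement on hand explains why the number falls with this change.

Still open, on these data alone, is whether the higher number of compound 1 extends to other amines at this carbon, such as ethylamino or morpholine. As far as these compounds go, the effect of the defined stereocentre also remains open, since only one stereoisomer of the entering group appears here.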